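Swapping the Sulfone Aryl Group in Compound 1

The compounds below may be only part of what the source reports. "The series", "measured", "known", "first", "only" and "open" are said of these compounds alone.

In an assay on isolated protein for displacement of a labelled ligand from metabotropic glutamate receptor 5 (Homo sapiens), with a stated time of 60 min, tested at 1 uM (on this read-out higher numbers stand for more inhibition at the one concentration tested (going by the name of the read-out) and lower numbers for less inhibition), compound 1 `COc1ccc2ncc(S(=O)(=O)c3ccc(OC)c(OC)c3)c(N3CCC(C)CC3)c2c1` gives -3%, the lowest of the three numbers measured. Going by the values given here, compound 2 `CC1CCN(c2c(S(=O)(=O)c3cc(F)cc(F)c3)cnc3c(F)cccc23)CC1` gives 9%, and compound 3 `COc1ccc(S(=O)(=O)c2cnc3ccc(Cl)cc3c2N2CCC(C)CC2)cc1OC` gives 61%; the step of a number 64 percentage points higher from compound 1 to compound 3 (beyond the scatter) is the only one-place change measured, and it concerns the shared core, not the sulfonyl side. Compound 4 `COc1ccc2ncc(S(=O)(=O)c3cccc(Cl)c3)c(N3CCC(C)CC3)c2c1` is made from compound 1 by the change (3-chlorophenyl in place of 3,4-dimethoxyphenyl on a sulfonyl sulfur). Among the compounds with values here, no measured step touches this position, so nothing here shows how this assay answers to it. Compound 2, which also carries a halogen-bearing ring on the sulfonyl sulfur, gives a low number, which suggests only a modest rise. Compound 4 is therefore expected at 15%, between -10% and 45%, an estimated step of a number 18 percentage points higher from compound 1 to compound 4 (beyond the scatter).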

Compound 4, a percentage reported as inhibition, at one concentration (the size of the read-out at that concentration, not a potency): -3%
For compound 4 the middle estimate is 18 percentage points above the measured one; the range from low to high includes it.
By their numbers in this assay, from the lowest: compounds 1 and 4 (each within the scatter of the next); then compound 2; then compound 3.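

Putting 3-chlorophenyl in place of 3,4-dimethoxyphenyl on a sulfonyl sulfur gives, in this assay, no change at the digits printed from compound 1 to compound 4 (within the scatter). On the core of compound 1, then, this swap does not lift the inhibition seen at the one concentration tested, and the methoxy groups of the leaving ring are not needed to keep the number where it stands. No available evidence accounts for this result.

As far as these compounds go, whether the same swap would hold on the chlorine-bearing core of compound 3 remains open. So does the outcome for a sulfonyl ring carrying an amine or a carboxylic acid.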